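The source may report more compounds than this note shows. Statements on the series, on what has been measured and on what is new or still open speak of the compounds shown alone.

In a functional assay on HepG2 cells (Homo sapiens) for inhibition, read by MTT assay, with a stated time of 48 h (a lower number here means a stronger inhibitor, a higher number a weaker inhibitor), compound 1 (`COc1ccc(-n2c(SCc3ccccc3)nnc2-c2cc(OC)c(OC)c(OC)c2)cc1`) gives > 60000 nM, which is a limit of the assay and not a number. Its standing is therefore only bounded: the limit of > 60000 nM in this assay, at which 1 of the 2 values shown sits. The change followed here leads to compound 3 (`COc1ccc(-n2c(SCC(=O)c3ccc(OC)c(O)c3)nnc2-c2cc(OC)c(OC)c(OC)c2)cc1`), in which (3-hydroxy-4-methoxyphenyl)carbonyl stands in place of phenyl on a saturated chain carbon bound to a sulfur: (3-hydroxy-4-methoxyphenyl)carbonyl in place of phenyl on a saturated chain carbon bound to a sulfur. Going by the values given here, one measured step bears on this change. Compound 2 (`COc1ccc(-n2c(SCC(=O)c3ccccc3)nnc2-c2cc(OC)c(OC)c(OC)c2)cc1`) carries benzoyl at that place and gives 16200 nM in this assay. Swapping phenyl for benzoyl gave an at least 3.7-fold lower number from compound 1 to compound 2 (0.56 log units; beyond the scatter), and the group entering here contains the same carbonyl, so a step in the same direction, toward a lower number in this assay, is expected, of similar or somewhat larger size. Among the compounds with values here, no measured step shows what the hydroxy and methoxy on the ring contribute, so the uncertainty is wide. The expected step is an at least 7.5-fold lower number from compound 1 to compound 3 (0.87 log units; beyond the scatter). For compound 3 the estimated value is 8000 nM, within an expected range from 1800 nM to 30000 nM.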

Compound 3, half-maximal inhibitory concentration: > 60000 nM
Compound 3: only a limit was reported (the forecaster's own chance of this, stated with the estimate: 10%); middle value at least 7.5-fold (0.87 log units) from the limit.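

Compound 3 shows that the carbonyl on the chain does not bring a lower number with every ring attached to it: in this assay, 3-hydroxy-4-methoxyphenyl in place of phenyl on a carbonyl carbon gives an at least 3.7-fold higher number from compound 2 to compound 3 (0.56 log units; beyond the scatter). The value of compound 3, > 60000 nM, is a limit of the assay and not a number, and the step that links it to compound 1, itself reported only as a limit, cannot be read. The gain seen with benzoyl therefore depends on the ring as well as on the carbonyl, and among these compounds only compound 2 gives a number, while the other two stand at the same limit: the limit of > 60000 nM in this assay, at which 2 of the 3 values shown sit.

The compounds shown do not separate the hydroxy from the methoxy, so it remains open whether one of them alone accounts for the higher number or whether it takes both. Also open, from the compounds shown here alone, is how this place would respond to an amine or a carboxylic acid on the ring, or to a longer chain on the sulfur, and whether any of these would give a number lower than that of compound 2, 16200 nM.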